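The compounds below may be only part of what the source reports. "The series", "measured", "known", "first", "only" and "open" are said of these compounds alone.

Compound 1 `O=S(=O)(c1ccc(-c2ccc3ncnc(Nc4ccc(OCc5ccccc5)c(Cl)c4)c3c2)cc1)N1CCOCC1` and compound 2 `COc1cccc(COc2ccc(Nc3ncnc4ccc(-c5ccc(S(=O)(=O)N6CCOCC6)cc5)cc34)cc2Cl)c1` share one core and differ in a single spot: methoxy in place of hydrogen on an aromatic carbon. In an ADME assay on HepG2 cells (Homo sapiens) for cytotoxicity, read by MTT assay, with a stated time of 48 h (on this read-out lower numbers stand for stronger inhibition and higher numbers for weaker inhibition), compound 1 gives only a limit, > 15000 nM. Compound 2 likewise gives only a limit, > 15000 nM. The step that the two limits leave unreadable from compound 1 to compound 2 therefore cannot be sized, because both readings sit at the limit of > 15000 nM in this assay, at which 3 of the 3 values shown sit. Compound 3 `O=S(=O)(c1ccc(-c2ccc3ncnc(Nc4ccc(OCc5cccc(F)c5)cc4)c3c2)cc1)N1CCOCC1` is built on a different core; how its core differs from that of compound 1 is not broken down here. In this assay compound 3 gives only a limit, > 15000 nM. Compound 4 `COc1cc(Nc2ncnc3ccc(-c4ccc(S(=O)(=O)N5CCOCC5)cc4)cc23)ccc1OCc1cccc(F)c1` carries the same kind of change as compound 2: methoxy in place of hydrogen on an aromatic carbon. The surroundings are not identical, since in compound 4 the new group stands ortho to a (3-fluorobenzyl)oxy group, while in compound 2 it is described only as meta to a large group. Compound 3 already sits at the limit of > 15000 nM in this assay, at which 3 of the 3 values shown sit, so the step that the limit leaves unreadable from compound 3 to compound 4 is expected to stay small. Compound 4 is estimated at 20000 nM, most likely reported once more only as a limit.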

Compound 4, half-maximal inhibitory concentration: > 15000 nM
Compound 4: a limit, no number; the forecaster's own chance of this, stated with the estimate: 85%; the middle value lies beyond the limit too.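

The step from compound 3 to compound 4 cannot be read, as both give only a limit in this assay: the limit of > 15000 nM in this assay, at which 4 of the 4 values shown sit. The compounds shown leave open whether methoxy in place of hydrogen changes the reading at all.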